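The source may report more compounds than this note shows. Statements on the series, on what has been measured and on what is new or still open speak of the compounds shown alone.

Working notes on the series. In a functional assay on SGC-7901 cells (Homo sapiens) for antiproliferative activity, read by MTT assay, with a stated time of 24 h (on this read-out lower numbers stand for stronger inhibition and higher numbers for weaker inhibition), compound 1 `Cc1cccc(NNC(=O)c2ccc(NS(=O)(=O)c3cnc(O)nc3O)cc2)c1` gives > 20000 nM, which is a limit and not a number. Compound 2 `O=C(NNc1ccccc1Cl)c1ccccc1NS(=O)(=O)c1cnc(O)nc1O` gives > 20000 nM, also a limit. Compound 3 `O=C(NNC(=O)c1ccccc1F)c1cccc(NS(=O)(=O)c2cnc(O)nc2O)c1` gives > 20000 nM, again a limit.

Compound 2 therefore has no rank of its own among the measured compounds, and the position is summed up as the limit of > 20000 nM in this assay, at which 3 of the 3 values shown sit. Among the compounds with values here, no step between measured compounds is available to size a structural change in this assay.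

The next entry is compound 4 `Cc1ccc(C(=O)NNC(=O)c2ccccc2NS(=O)(=O)c2cnc(O)nc2O)cc1`. Its difference from compound 2 is (4-methylphenyl)carbonyl in place of 2-chlorophenyl on an amine nitrogen.

Compound 3 also carries a carbonyl group on the corresponding nitrogen, and its reading of > 20000 nM is a limit, so that feature alone gives no ground to expect a gain. The expected step that the limit leaves unreadable from compound 2 to compound 4 is none beyond the scatter, with no direction favoured. Compound 4 will most likely report as a limit as well. For compound 4 the estimated value is 22000 nM, with an expected range from 9000 nM to 50000 nM.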

Compound 4, half-maximal inhibitory concentration: 15500 nM
Compound 4: middle estimate off by 1.4-fold (0.15 log units), on the high side; measured number inside the range.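

In this assay, within the data shown here, compound 4 gives 15500 nM, the only value shown so far that is a number and not a limit, so this position now has one reading that later changes can be sized against. From the compounds shown here alone, putting (4-methylphenyl)carbonyl in place of 2-chlorophenyl on an amine nitrogen gives an at least 1.2-fold lower number from compound 2 to compound 4 (0.11 log units; that floor lies within the scatter), which does not establish a gain, and the true size of the step stays unknown as long as compound 2 is held only by its limit. The change therefore shows that a number can be reached with this group at this place, but not that the group improves on 2-chlorophenyl, and the rest of the series gives no reading to set beside it: the limit of > 20000 nM in this assay, at which 3 of the 4 values shown sit.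

The compounds shown do not separate the part played by the carbonyl from that of the methyl on the ring in the group that enters. Going by these compounds, it also remains open whether an amine or a carboxylic acid in place of that methyl would move the reading of compound 4 beyond the scatter.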